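The source may hold more compounds than are shown below. What is called first, only, known or untested is meant among the compounds shown, and "the series" means these compounds.

Measured so far in a functional assay on CHO cells for antagonist activity at C-C chemokine receptor type 4 (Homo sapiens), read by radioligand binding and GTPgammaS binding; on this read-out higher numbers stand for weaker inhibition and lower numbers for stronger inhibition:
compound 1 `COc1cccc2c1c(NS(=O)(=O)c1cccc(Cl)c1Cl)nn2C` gives 603 nM
compound 2 `COc1cc2c(cc1NS(=O)(=O)c1cccc(Cl)c1Cl)[nH]c(=O)n2C` gives 200 nM
compound 3 `COc1cc2c(cc1NS(=O)(=O)c1cccc(Cl)c1Cl)[nH]c(=O)n2C(C)C` gives 1000 nM

Compound 3 holds the highest of the three numbers in this assay. Its nearest neighbour is compound 1, whose number lies within the usual scatter of that of compound 3, so nothing can be said about their order. Its furthest neighbour is compound 2: the step of a 5.0-fold higher number from compound 2 to compound 3 (0.70 log units; beyond the scatter), isopropyl in place of methyl on an aromatic nitrogen, is modest but lies beyond the scatter.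

Compound 4 `COc1cc2c(cc1NS(=O)(=O)c1cccc(Cl)c1Cl)[nH]c(=O)n2C1CN(C(C)=O)C1` follows from compound 3 by a change at that same nitrogen: 1-acetylazetidin-3-yl in place of isopropyl on an aromatic nitrogen. For the measured compounds named here, only the step from compound 2 to compound 3 bears on it, and that step went toward a higher number when the group on this nitrogen was exchanged. The incoming 1-acetylazetidin-3-yl is not covered by any measured pair, so the direction is uncertain. Compound 4 is therefore expected to stay close to compound 3, with an estimated step of a 1.3-fold lower number from compound 3 to compound 4 (0.10 log units; within the scatter), and an estimated value of 800 nM within a range from 250 nM to 2500 nM.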

Compound 4, half-maximal inhibitory concentration: 200 nM
Compound 4: the middle estimate sits 4.0-fold (0.60 log units) above what was measured; measured number below the stated range.
By their numbers in this assay, from the lowest: compounds 2 and 4 (each within the scatter of the next); then compounds 1 and 3 (each within the scatter of the next).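

In this assay, the earlier pair at this aromatic nitrogen had shown only a move toward a higher number, from methyl to isopropyl. The new result shows that a group with more heavy atoms does not in itself bring a higher number here: 1-acetylazetidin-3-yl, with its four-membered ring and a hydrogen-bond acceptor that isopropyl lacks, gives a 5.0-fold lower number from compound 3 to compound 4 (0.70 log units; beyond the scatter) and, against the small methyl, no change at the digits printed from compound 2 to compound 4 (within the scatter). Nothing in the data shown accounts for the difference between isopropyl and 1-acetylazetidin-3-yl.

Going by these compounds, whether the ring or the acetyl carbonyl carries that difference stays open. So does whether a cyclobutyl ring, the free azetidine amine or a longer acyl chain on this nitrogen would hold the number of compound 4 or lose it.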